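Amide aryl exchange on the shared core: cytotoxicity notes

This account rests on a few compounds, and the source may have more. Where it says the series, first, only, none or still open, it means among the compounds named here.

Compound 1 `O=C(Nc1ccc(OC(F)F)cc1)c1cccc(/C=C2\CC(=O)N(c3ccccc3)C2=O)c1` sits at the top of the measured range in an ADME assay on HCT-116 cells (Homo sapiens) for cytotoxicity, read by MTT assay, with a stated time of 72 h; on this read-out lower numbers stand for stronger inhibition and higher numbers for weaker inhibition. In this assay compound 1 gives > 100000 nM, which is a limit of the assay rather than a number. Compound 2 `Cc1ccc(N2C(=O)C/C(=C\c3cccc(C(=O)Nc4ccc(Cl)cc4)c3)C2=O)cc1` returns the same kind of limit in this assay, > 100000 nM. Among the compounds with values here, compound 3 `CCCCNC(=O)c1cccc(/C=C2\CC(=O)N(Cc3ccccc3)C2=O)c1` is the only member with a numerical value, giving 95100 nM in this assay. Compound 1 therefore stands at the limit of > 100000 nM in this assay, at which 2 of the 3 values shown sit. Within the data shown here, the one measured number, that of compound 3, lies close to that limit. Among the measured compounds shown here, no pair among the measured compounds differs in a single place, so no measured step is available to read a trend from.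

Compound 4 `CSc1cccc(NC(=O)c2cccc(/C=C3\CC(=O)N(c4ccccc4)C3=O)c2)c1` is not yet measured. It differs from compound 1 by 3-(methylsulfanyl)phenyl in place of 4-(difluoromethoxy)phenyl on an amide-type nitrogen. With the whole series at or near the limit, and compound 1 itself only a limit in this assay, no direction can be drawn for this change. The step from compound 1 to compound 4 is expected to be none beyond the scatter, a step that the limit leaves unreadable from compound 1 to compound 4. Compound 4 is accordingly estimated at 120000 nM in this assay, with a range of 40000 nM to 300000 nM, and most probably reported once more as a limit.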

Compound 4, half-maximal inhibitory concentration: 65200 nM
The estimate for compound 4 lay 1.8-fold (0.26 log units) above the measured number; the measured number falls inside the stated range.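

With 3-(methylsulfanyl)phenyl in place of 4-(difluoromethoxy)phenyl on an amide-type nitrogen, this assay gives the series its first readable step: an at least 1.5-fold lower number from compound 1 to compound 4 (0.18 log units; that floor lies within the scatter). Compound 1 is only a limit, so this step is a floor: the true size may be larger, but the floor alone does not establish a change beyond the scatter. What is new is that a group at this place on the shared core can bring a measured number where compound 1 gives none, although the limit still holds for part of the series: the limit of > 100000 nM in this assay, at which 2 of the 4 values shown sit.

Left open is whether the difference follows the group itself or where it sits on the phenyl ring, a question that 4-(methylsulfanyl)phenyl or 3-(difluoromethoxy)phenyl on the same nitrogen would address on the core of compound 1. Also open, going by these compounds, is whether a dimethylamino or carboxylic acid group on that phenyl ring would move the number further from the limit or return it there.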